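Two inactive sulfonamides and a chlorothiophene variant

The source may report more compounds than this note shows. Statements on the series, on what has been measured and on what is new or still open speak of the compounds shown alone.

Measured so far:
compound 1 `Cc1ccccc1S(=O)(=O)Nc1ccc2oc(-c3ccccc3)nc2c1`: > 100000 nM
compound 2 `CCc1ccc(S(=O)(=O)Nc2ccc(-c3nc4ccccc4o3)cc2)cc1`: > 100000 nM

In an assay on cells for inhibition of HSP60/HSP10 (Homo sapiens), with a stated time of 60 min (on this read-out lower numbers stand for stronger inhibition and higher numbers for weaker inhibition), compound 1 gives > 100000 nM, which is a limit of the assay and not a number. Compound 2 gives > 100000 nM, also a limit. Compound 1 therefore stands at the limit of > 100000 nM in this assay, at which 2 of the 2 values shown sit, the weak end of what this assay reports. Compound 3 `O=S(=O)(Nc1ccc2oc(-c3ccccc3)nc2c1)c1ccc(Cl)s1` differs from compound 1 by 5-chlorothiophen-2-yl in place of 2-methylphenyl on a sulfonyl sulfur. The step is expected to be a number no higher from compound 1 to compound 3 (the limit leaves the size open), that is none beyond the scatter. Compound 3 is estimated at 100000 nM, within 30000 nM to 300000 nM, and most likely again returned only as a limit.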

Compound 3, half-maximal inhibitory concentration: 70000 nM
Beside the measured number, compound 3's estimate is 1.4-fold (0.15 log units) above it; measured number inside the range.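

In this assay, among these compounds, compound 3 is the first to return a number rather than a limit, at 70000 nM. Exchanging the 2-methylphenyl group for the 5-chlorothiophen-2-yl group gives an at least 1.4-fold lower number from compound 1 to compound 3 (0.15 log units; that floor lies within the scatter), so the change is not shown to exceed the scatter. The value of compound 1 is a limit and not a number: the limit of > 100000 nM in this assay, at which 2 of the 3 values shown sit.

Still open, on these data alone, is whether an amine or a carboxylic acid in place of the chlorine of 5-chlorothiophen-2-yl would shift the number beyond the scatter. Also open, as far as these compounds go, is how 5-chlorothiophen-2-yl behaves on the core of compound 2.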